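This account rests on a few compounds, and the source may have more. Where it says the series, first, only, none or still open, it means among the compounds named here.

Measured compounds in a functional assay on VCaP cells (Homo sapiens) for antiproliferative activity, read by CCK-8 assay, with a stated time of 6 days; on this read-out lower numbers stand for stronger inhibition and higher numbers for weaker inhibition:
compound 1 `N#Cc1ccc(N2CCc3cc(-c4cnc5ccccc5c4)ccc3C2)cc1C(F)(F)F` gives > 30000 nM, which is a limit of this assay and not a number
compound 2 `Cc1noc(C)c1-c1cccc(Oc2ccc(C#N)c(C(F)(F)F)c2)c1` gives "not determined" (no result reported) in this assay
compound 3 `CCN(c1ccc(C#N)c(Cl)c1)c1cc(-c2ccoc2)ccc1C` gives 4010 nM

Compound 3 thus holds the only number shown in this assay; the one further value shown is a limit, namely (the limit of > 30000 nM in this assay, at which 1 of the 3 values shown sits), and one further entry carries no number at all. Compound 4 `CCN(c1ccc(C#N)c(Cl)c1)c1cc(-c2c[nH]nc2C)ccc1C` differs from compound 3 by 3-methyl-1H-pyrazol-4-yl in place of furan-3-yl on an aromatic carbon. No step between measured compounds is shown, so the size of this change cannot be read off from any neighbouring pair. The step in this assay is expected to be small, within the scatter or only a little beyond it, at a 1.6-fold lower number from compound 3 to compound 4 (0.21 log units; within the scatter). Compound 4 is therefore expected to give 2500 nM in this assay, with a range from 800 nM to 8000 nM.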

Compound 4, half-maximal inhibitory concentration: 3190 nM
Compound 4: middle estimate off by 1.3-fold (0.11 log units), on the low side; low and high end bracket the measured number.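

In this assay, the aromatic carbon para to a methyl group takes 3-methyl-1H-pyrazol-4-yl in place of furan-3-yl with a 1.3-fold lower number from compound 3 to compound 4 (0.10 log units; within the scatter). This first readable step in the series shows that a ring carrying a hydrogen-bond donor can stand at this position with no change beyond the scatter. No measurement shown bears on why the two rings read alike.

Open, going by these compounds, is whether the methyl group on the pyrazole matters, which would take the plain 1H-pyrazol-4-yl to read. Also open, on these data alone, is whether an amine or a carboxylic acid at this carbon would move the number.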